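The source may hold more compounds than are shown below. What is called first, only, known or untested is meant among the compounds shown, and "the series" means these compounds.

Measured so far in a functional assay on MCF7 cells (Homo sapiens) for antiproliferative activity, read by MTT assay, with stated times of 24 h and 72 h; on this read-out lower numbers stand for stronger inhibition and higher numbers for weaker inhibition:
compound 1 `COc1ccc([C@@H]2[C@H](Oc3ccccc3)C(=O)N2c2cc(OC)c(OC)c(OC)c2)cc1`: 35000 nM
compound 2 `COc1ccc([C@@H]2[C@H](Oc3ccccc3)C(=O)N2c2cc(OC)c(OC)c(OC)c2)cc1OC`: 26000 nM
compound 3 `COc1cc(N2C(=O)[C@@H](Oc3ccccc3)[C@H]2c2ccc([N+](=O)[O-])cc2)cc(OC)c1OC`: 63000 nM

All three numbers in this assay sit within the scatter of one another; compound 1 differs from compound 2 by a 1.3-fold lower number from compound 1 to compound 2 (0.13 log units; within the scatter) and from compound 3 by a 1.8-fold higher number from compound 1 to compound 3 (0.26 log units; within the scatter), so no ordering among them is supported.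

Compound 4 `COc1cc(N2C(=O)[C@@H](Oc3ccccc3)[C@H]2c2ccc(SC)cc2)cc(OC)c1OC` is the next member. Relative to compound 1 the change is methylsulfanyl in place of methoxy on an aromatic carbon. Among the measured compounds shown here, no measured step replaces methoxy by methylsulfanyl. For the measured compounds named here, the only step at the same aromatic carbon, a 1.8-fold higher number from compound 1 to compound 3 (0.26 log units; within the scatter), stays within the scatter, as does a 1.3-fold lower number from compound 1 to compound 2 (0.13 log units; within the scatter) on the other aryl ring. The expectation for compound 4 is therefore no step beyond the scatter, a 1.2-fold lower number from compound 1 to compound 4 (0.07 log units; within the scatter). Compound 4 is estimated at 30000 nM, range 12000 nM to 70000 nM.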

Compound 4, half-maximal inhibitory concentration: 7700 nM
The estimate for compound 4 lay 3.9-fold (0.59 log units) above the measured number; the whole stated range lies above it.
By their numbers in this assay, from the lowest: compound 4; then compounds 2, 1 and 3 (each within the scatter of the next, the first and the last beyond it).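

In this assay, this aromatic carbon, para to a large group, no longer looks indifferent to its substituent: methylsulfanyl gives a 4.5-fold lower number from compound 1 to compound 4 (0.66 log units; beyond the scatter) and an 8.2-fold lower number from compound 3 to compound 4 (0.91 log units; beyond the scatter), whereas methoxy and nitro stayed within the scatter of each other. The 4-(methylsulfanyl)phenyl compound also stands apart from the 3,4-dimethoxyphenyl one, with a 3.4-fold lower number from compound 2 to compound 4 (0.53 log units; beyond the scatter). No measured property is available to account for these steps.

Open, on these data alone, is whether the sulfur atom itself or the group as a whole carries the step. As far as these compounds go, how ethylsulfanyl, methylsulfonyl or dimethylamino at this carbon would read remains unknown.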